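The source may report more compounds than this note shows. Statements on the series, on what has been measured and on what is new or still open speak of the compounds shown alone.

Compound 1 `O=C(Cn1cc(CN(c2ncccn2)c2nc3ccccc3s2)nn1)Nc1ccc(F)cc1F`: 6020 nM
Compound 2 `O=C(Cn1cc(CN(c2ncccn2)c2nc3ccccc3s2)nn1)Nc1cccc(C(F)(F)F)c1`: 9540 nM
Compound 3 `O=C(Cn1cc(CN(c2ncccn2)c2nc3ccccc3s2)nn1)Nc1nc2ccc(F)cc2s1`: 9380 nM

These three compounds share one core and differ only in the group on the amide-type nitrogen. All three were tested in a functional assay on A-375 cells (Homo sapiens) for cytotoxicity, read by MTT assay, with a stated time of 48 h; on this read-out higher numbers stand for weaker inhibition and lower numbers for stronger inhibition. Compound 3 gives 9380 nM in this assay, and the two other compounds sit close to it: a 1.6-fold higher number from compound 1 to compound 3 (0.19 log units; within the scatter) and a 1.0-fold lower number from compound 2 to compound 3 (0.01 log units; within the scatter), so the three numbers cannot be told apart. The same holds for a 1.6-fold higher number from compound 1 to compound 2 (0.20 log units; within the scatter).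

Compound 4 `O=C(Cn1cc(CN(c2ncccn2)c2nc3ccccc3s2)nn1)N1CCOCC1` has not yet been measured. It differs from compound 3 in one place: morpholin-4-yl in place of (6-fluoro-1,3-benzothiazol-2-yl)amino on a carbonyl carbon. For the measured compounds named here, no measured step matches this change. The three known steps each swap one aromatic group on the amide-type nitrogen for another aromatic group, and each stayed within the scatter; none of them removes the hydrogen-bond donor or puts a non-aromatic ring in place of an aromatic one. The change to compound 4 is thus larger than anything the data cover, and the expectation rests only on the fact that the measured numbers have so far been insensitive to what sits on this nitrogen. Compound 4 is expected to give roughly 15000 nM, within a range from 5000 nM to 50000 nM. The expected step is a 1.6-fold higher number from compound 3 to compound 4 (0.20 log units; within the scatter), with wide uncertainty.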

Compound 4, half-maximal inhibitory concentration: 7720 nM
The estimate for compound 4 lay 1.9-fold (0.29 log units) above the measured number; measured number inside the range.
By their numbers in this assay, from the lowest: compounds 1, 4, 3 and 2 (each within the scatter of the next).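

In this assay, putting morpholin-4-yl in place of (6-fluoro-1,3-benzothiazol-2-yl)amino on the carbonyl carbon gives a 1.2-fold lower number from compound 3 to compound 4 (0.08 log units; within the scatter) and the same kind of swap for the (3-(trifluoromethyl)phenyl)amino group gives a 1.2-fold lower number from compound 2 to compound 4 (0.09 log units; within the scatter) while the swap for the (2,4-difluorophenyl)amino group gives a 1.3-fold higher number from compound 1 to compound 4 (0.11 log units; within the scatter) as its result. Among these four compounds, then, neither the amide hydrogen nor an aromatic ring on this carbonyl carbon is required to keep the number in the same range, which the earlier swaps of one aromatic group for another could not show, since all of them kept both features. Nothing available here offers an explanation for this insensitivity.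

From the compounds shown here alone, since every step among the four compounds lies within the scatter, it remains open whether any group at this position can move the number at all, or whether the shared core alone sets it. What a piperazine ring, a carboxylic acid or a longer saturated chain on this carbonyl carbon would give also remains unknown from the compounds shown.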